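The source may report more compounds than this note shows. Statements on the series, on what has been measured and on what is new or still open speak of the compounds shown alone.

The account follows a single step within a small set of compounds that share one core. Within the data shown here, compound 1 `CC[C@@H]1C[C@H](CC)CN(CCCNC(=O)C2CCN(Cc3nc(-c4ccccc4C)oc3C)CC2)C1` is the reference point: in a physicochemical assay for permeability, using PAMPA (a lower number here means that the compound crosses the layer more slowly, a higher number that the compound crosses the layer faster), compound 1 gives 1270 10^-6 cm/s, and that is the only number recorded so far. Compound 2 `Cc1oc(-c2ccc(F)cc2)nc1CN1CCC(C(=O)NCCCN2C[C@H](C)C[C@H](C)C2)CC1` belongs to the same set, but in this assay compound 2 shows "not determined" (no result reported), so it offers no point of comparison. Compound 3 `Cc1ccccc1-c1nc(CN2CCC(C(=O)NCCN3C[C@H](C)C[C@H](C)C3)CC2)c(C)o1` is the next member to be tested. It differs from compound 1 in one place: 3,5-dimethylpiperidin-1-yl in place of (3,5-diethylpiperidin-1-yl)methyl on a saturated chain carbon, two bonds along the chain from an amide-type nitrogen. Among the measured compounds shown here, no measured pair shows how a change of this kind plays out in this assay, so the expectation rests on compound 1 alone, whose 1270 10^-6 cm/s sits at the high end of what such measurements return. The step of a 1.4-fold lower number from compound 1 to compound 3 (0.15 log units; within the scatter) is expected to be small, with a slight lean downward, and not clearly beyond the scatter. Compound 3 is therefore estimated at 900 10^-6 cm/s in this assay, with a range from 400 10^-6 cm/s to 1800 10^-6 cm/s.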

Compound 3, apparent permeability: 712 10^-6 cm/s
Beside the measured number, compound 3's estimate is 1.3-fold (0.10 log units) above it; the measured number falls inside the stated range.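

Among these compounds, the step gives the first reading of this position in this assay: 3,5-dimethylpiperidin-1-yl in place of (3,5-diethylpiperidin-1-yl)methyl gives a 1.8-fold lower number from compound 1 to compound 3 (0.25 log units; within the scatter). This change, from a group of 11 heavy atoms to one of 8, on a saturated chain carbon, two bonds along the chain from an amide-type nitrogen, therefore leaves a difference that cannot be told from the usual scatter of repeated measurements. Nothing at hand gives a reason for the size of this step.

The single step alters the chain and the ring substituents together, so the compounds shown do not separate the two, and compound 2 offers no step that can be read. From the compounds shown here alone, whether a morpholine or a primary amine in place of the 3,5-dimethylpiperidin-1-yl group would also stay within the scatter remains open.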